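This account rests on a few compounds, and the source may have more. Where it says the series, first, only, none or still open, it means among the compounds named here.

Compound 2 `CNCc1cn(S(=O)(=O)c2cc(OC)ccn2)c(-c2cccnc2F)c1F` gives 0.51 in a physicochemical assay for lipophilicity, read by HPLC, at pH 7.4; on this read-out higher numbers stand for higher lipophilicity and lower numbers for lower lipophilicity. Among the three measured compounds it stands second highest: compound 1 `CNCc1cn(S(=O)(=O)c2ccoc2)c(-c2cccnc2F)c1F`, which gives 0.45, lies within the scatter of compound 2, while compound 3 `CNCc1cn(S(=O)(=O)c2cncc(F)c2)c(-c2cccnc2F)c1F` gives 0.83. The change leading to compound 4 `CNCc1cn(S(=O)(=O)c2cccnc2C)c(-c2cccnc2F)c1F` is 2-methylpyridin-3-yl in place of 4-methoxypyridin-2-yl on a sulfonyl sulfur. The step that bears most directly on it is the one in which 5-fluoropyridin-3-yl replaced the same group: a number 0.32 log units higher from compound 2 to compound 3 (beyond the scatter). The related steps of a number 0.06 log units higher from compound 1 to compound 2 (within the scatter) and a number 0.38 log units higher from compound 1 to compound 3 (beyond the scatter) point the same way. Compound 4 is therefore expected to show a modest rise in this assay, a number 0.29 log units higher from compound 2 to compound 4 (within the scatter). The estimate for compound 4 is 0.8, with a range from 0.45 to 1.15.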

Compound 4, distribution coefficient: 0.48
Compound 4: middle estimate off by 0.32 log units, on the high side; measured number inside the range.
By their numbers in this assay, from the lowest: compounds 1, 4 and 2 (each within the scatter of the next); then compound 3.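

In this assay the step to 2-methylpyridin-3-yl on the sulfonyl sulfur is a number 0.03 log units lower from compound 2 to compound 4 (within the scatter) and the step from furan-3-yl is a number 0.03 log units higher from compound 1 to compound 4 (within the scatter) so three different groups at this position now read alike. Only 5-fluoropyridin-3-yl stands apart from the new group, with a number 0.35 log units lower from compound 3 to compound 4 (beyond the scatter) as the step that shows it. Nothing measured here offers an explanation for this. The compounds shown leave open whether the fluoro group itself sets compound 3 apart, and how an amine or a carboxylic acid on the pyridine ring would read in this assay at this position.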